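Cytotoxicity notes: amide to acid in a small series

The source may hold more compounds than are shown below. What is called first, only, known or untested is meant among the compounds shown, and "the series" means these compounds.

- compound 1 `NC(=O)/C=C/[C@H]1C[C@@H](O)[C@@H](O)C1`: in an ADME assay on S2 cells (Drosophila melanogaster) for cytotoxicity, read by MTT assay (a lower number here means that less compound is needed, a higher number that more compound is needed for the effect), compound 1 gives > 250000 nM, which is an assay limit and not a number.
- compound 2 `O=C(/C=C/[C@H]1C[C@@H](O)[C@@H](O)C1)N1CCCCC1`: in this assay compound 2 gives > 250000 nM, likewise only a limit.

Compound 1 therefore stands at the limit of this assay, with no number of its own; the evidence is the limit of > 250000 nM in this assay, at which 2 of the 2 values shown sit. Compound 3 `O=C(O)/C=C/[C@H]1C[C@@H](O)[C@@H](O)C1` differs from compound 1 by hydroxy in place of amino on a carbonyl carbon. For the measured compounds named here, no step between measured compounds is known. Because compound 1 sits at the limit of > 250000 nM in this assay, at which 2 of the 2 values shown sit, the step that the limit leaves unreadable from compound 1 to compound 3 is expected to be none beyond the scatter. Compound 3 is thus estimated at 300000 nM, with a range from 100000 nM to 1000000 nM, most likely again reported only as a limit.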

Compound 3, half-maximal effective concentration: > 350000 nM
Compound 3 ended at the assay's limit; the forecaster's own chance of this, stated with the estimate: 90%; at least 1.1-fold (0.06 log units) between middle value and limit.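

For the compounds shown here, compound 1 and compound 3 are both reported only as limits, and no step between them can be read. The compounds shown leave open at what concentration any of them reaches the effect in this assay.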